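Chloro for cyano on the benzyl group of compound 2

The source may hold more compounds than are shown below. What is called first, only, known or untested is meant among the compounds shown, and "the series" means these compounds.

Three members of the series have been measured, and all three sit at the same limit. Among the measured compounds shown here, compound 1 `N#Cc1ccc(Cn2cncc2CNc2ccc(C(=O)NCc3ccccc3)c(-c3ccccc3)c2)cc1` is the first. In a functional assay on NIH3T3 cells (Mus musculus) (a higher number here means that more compound is needed for the effect, a lower number that less compound is needed), compound 1 reaches only the limit > 10 uM and gives no number. Compound 2 `COC(=O)[C@H](CCSC)NC(=O)c1ccc(NCc2cncn2Cc2ccccc2C#N)cc1-c1ccccc1` is the second. In this assay compound 2 likewise stops at the limit > 10 uM without a number. Compound 3 `CSCC[C@H](NC(=O)c1ccc(NCc2cncn2Cc2ccccc2C#N)cc1-c1ccccc1)C(=O)O` is the third. In this assay compound 3 also returns only the limit > 10 uM and no number. For the measured compounds named here, the single one-place step between measured compounds, a step that the two limits leave unreadable from compound 2 to compound 3, therefore cannot be read. The whole of the evidence is the limit of > 10 uM in this assay, at which 3 of the 3 values shown sit, and nothing more.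

Compound 4 `COC(=O)[C@H](CCSC)NC(=O)c1ccc(NCc2cncn2Cc2ccccc2Cl)cc1-c1ccccc1` differs from compound 2 in one place: chloro in place of cyano on an aromatic carbon. Going by the values given here, no measured step bears on this change, and compound 2 itself stands only at a limit, so the data give neither a size nor a direction for the step. The step meant by the estimate, a step that the limit leaves unreadable from compound 2 to compound 4, is expected to stay within the scatter. Compound 4 is thus expected to give about 20 uM in this assay, with a range from 5 uM to 100 uM, and most likely again only a limit is reported.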

Compound 4, concentration for half-maximal effect: > 10 uM
Compound 4 ended at the assay's limit; the forecaster's own chance of this, stated with the estimate: 85%; the middle value is on the limit's open side.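

Compound 2 and compound 4 both stop at a limit in this assay, and the step between them, chloro in place of cyano, cannot be read. The series still rests on one observation: the limit of > 10 uM in this assay, at which 4 of the 4 values shown sit.

The compounds shown leave open what concentration any member of the series needs in this assay, and whether 2-cyanobenzyl and 2-chlorobenzyl differ at all.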